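From Isopentyloxy to Isobutoxy in Compound 3

The compounds below may be only part of what the source reports. "The series", "measured", "known", "first", "only" and "open" are said of these compounds alone.

Measured in a functional assay on PC-3 cells (Homo sapiens) for antiproliferative activity, read by sulforhodamine B assay; on this read-out higher numbers stand for weaker inhibition of growth and lower numbers for stronger inhibition of growth:
- Compound 1 `O=C(/C=C/c1ccc(O)cc1)c1c(O)cccc1OCCC1CCCCC1`: > 30000 nM (a limit)
- Compound 2 `CC(C)CCOc1cccc(O)c1C(=O)/C=C/c1ccc(O)cc1`: 11500 nM

In this assay, within the data shown here, compound 2 holds the only exact number so far, 11500 nM. Compound 1 is known only by its limit, > 30000 nM.

Among the measured compounds shown here, the one measured step is an at least 2.6-fold lower number from compound 1 to compound 2 (0.41 log units; beyond the scatter). It places isopropyl in place of cyclohexyl on a saturated chain carbon, two bonds along the chain from an oxygen on an aromatic ring. From the compounds shown here alone, that step starts from a limit, so its full size is unknown.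

Compound 3 `CC(C)COc1cccc(O)c1C(=O)/C=C/c1ccc(O)cc1` differs from compound 2 by isopropyl in place of isobutyl on a saturated chain carbon bound to an oxygen on an aromatic ring. In words, isopropyl stands in place of isobutyl on a saturated chain carbon bound to an oxygen on an aromatic ring, which turns isopentyloxy into isobutoxy. A single step is thin support, and this change is a much smaller one, so only a slight drift toward a lower number is expected, probably within the scatter. The expected step is a 1.3-fold lower number from compound 2 to compound 3 (0.11 log units; within the scatter). Compound 3 is estimated at 9000 nM, with an expected range from 4000 nM to 22000 nM.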

Compound 3, concentration for 50% growth inhibition: 2970 nM
Estimate against measurement, compound 3: 3.0-fold (0.48 log units) above; the measured number lies below the stated range.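

In this assay, the change from isopentyloxy to isobutoxy gives a 3.9-fold lower number from compound 2 to compound 3 (0.59 log units; beyond the scatter). The earlier step replaced a ring-bearing end with a branched chain, whereas this one keeps a branched chain without a ring and alters only its length, and even that small edit moves the number beyond the scatter, so this position is sensitive to more than the loss of the cyclohexyl ring. Across the three compounds shown, the number falls as the chain end goes from cyclohexylmethyl to isobutyl to isopropyl, with none going against that order, and the full span is an at least 10-fold lower number from compound 1 to compound 3 (1.00 log units; beyond the scatter), which remains only a bound: the limit of > 30000 nM in this assay, at which 1 of the 3 values shown sits.

The compounds shown leave open whether the fall continues with a still shorter chain such as ethoxy or methoxy, or reverses at some point, and whether chain length or the branch itself matters, which a straight butoxy chain would help to separate. They also do not tell how this position would respond to a chain ending in an amine or a carboxylic acid rather than in a plain hydrocarbon group.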